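A few compounds are considered here, and "the series" means these few. Any claim that something is new, unique, unknown or untested is made for them only; others in the source may bear on it.

Working notes on the series. Compound 1 `CCCCCCCCCCCCCCN(NC(=O)COC)C(=O)OC(C)(C)C`, compound 2 `CCCCCCCCCCN(NC(=O)COC)C(=O)OC(C)(C)C` and compound 3 `CCCCCCCCCCCC/C=C/N(NC(=O)COC)C(=O)OC(C)(C)C` have been tested; compound 4 `CCCCCCCC/C=C/N(NC(=O)COC)C(=O)OC(C)(C)C` has not. In a functional assay on HeLa cells (Homo sapiens) for cytotoxicity, with a stated time of 72 h (on this read-out lower numbers stand for higher toxicity in this test and higher numbers for lower toxicity in this test), compound 1 gives 41900 nM, compound 2 gives 104000 nM and compound 3 gives 57700 nM. The change hydrogen in place of butyl on a saturated chain carbon, ten or more bonds along the chain from an amide-type nitrogen produced a 2.5-fold higher number from compound 1 to compound 2 (0.39 log units; beyond the scatter). Compound 4 carries the same kind of change on compound 3, (hydrogen in place of butyl on a saturated chain carbon, eight bonds along the chain from a double-bonded chain carbon); the place is not identical, being counted along the chain from a double-bonded chain carbon rather than from an amide-type nitrogen. How the core of compound 3 differs from the core of compound 1 is not broken down here. For compound 4 a modest step of the earlier size is expected, a 2.4-fold higher number from compound 3 to compound 4 (0.38 log units; beyond the scatter), resting on a 2.5-fold higher number from compound 1 to compound 2 (0.39 log units; beyond the scatter). Compound 4 is therefore estimated at 140000 nM, between 85000 nM and 230000 nM.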

Compound 4, half-maximal cytotoxic concentration: 83200 nM
The estimate for compound 4 lay 1.7-fold (0.23 log units) above the measured number; the whole stated range lies above it.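

In this assay, the change from butyl to hydrogen gives a 1.4-fold higher number from compound 3 to compound 4 (0.16 log units; within the scatter), a step that on its own cannot be told from no change. Set beside the earlier step, it does not differ measurably: the same change on two cores in this assay, a 2.5-fold higher number (0.39 log units; beyond the scatter) from compound 1 to compound 2 and a 1.4-fold higher number (0.16 log units; within the scatter) from compound 3 to compound 4, 1.7-fold (0.24 log units) apart, within the scatter of two such steps

The change therefore carries between these two cores without a measurable difference in step size, but two pairs do not fix a size for it, and they do not show that it would hold on any other core. The compounds shown leave open whether a longer chain, or an amine or a carboxylic acid in place of butyl, would give steps of similar size on either core.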